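Compound 1 to compound 4: a carbonyl-linked group replaces an aryl group

The source may hold more compounds than are shown below. What is called first, only, known or untested is meant among the compounds shown, and "the series" means these compounds.

In an ADME assay on HCT-116 cells (Homo sapiens) for cytotoxicity, read by CellTiter-Glo, with a stated time of 72 h (on this read-out higher numbers stand for weaker inhibition and lower numbers for stronger inhibition), compound 1 `Cc1ccc(C2CCN(S(=O)(=O)c3c(C)cc(C)cc3C)CC2)cc1` gives > 5000 nM, which is a limit of the assay and not a number. Compound 2 `CC1CCN(C2CCN(S(=O)(=O)c3cn(C)cn3)CC2)CC1` gives > 10000 nM, also a limit. Compound 3 `CC1CCN(C2CCN(S(=O)(=O)c3ccc(Cl)c(C(F)(F)F)c3)CC2)CC1` gives > 5000 nM, again a limit. Within the data shown here, compound 1 therefore has no numerical position, and no measured compound here provides a number for comparison.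

Compound 4 `Cc1cc(C)c(S(=O)(=O)N2CCC(C(=O)N3CCC(C)CC3)CC2)c(C)c1` keeps the core of compound 1 and differs by (4-methylpiperidin-1-yl)carbonyl in place of 4-methylphenyl on a saturated ring carbon. In words, (4-methylpiperidin-1-yl)carbonyl stands in place of 4-methylphenyl on a saturated ring carbon.

Among the measured compounds shown here, no step between measured compounds is available to size this change in this assay. The expectation rests on compound 1 and its limit of > 5000 nM. The expected step that the limit leaves unreadable from compound 1 to compound 4 is none beyond the scatter, in either direction. A further limit is the most likely report for compound 4. For compound 4, the estimated value is 8000 nM, with an expected range from 3000 nM to 20000 nM.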

Compound 4, half-maximal inhibitory concentration: > 5000 nM
Compound 4: only a limit was reported (the forecaster's own chance of this, stated with the estimate: 85%); the middle value lies beyond the limit too.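

Among these compounds, no step between compound 1 and compound 4 can be read in this assay: both results are limits of the assay and not numbers. The compounds shown leave open what (4-methylpiperidin-1-yl)carbonyl in place of 4-methylphenyl does to cytotoxicity, and whether any compound in this series gives a numerical value.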